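The source may hold more compounds than are shown below. What is called first, only, known or untested is meant among the compounds shown, and "the series" means these compounds.

Measured in a functional assay on SK-BR-3 cells (Homo sapiens) for antiproliferative activity; a lower number here means a stronger inhibitor, a higher number a weaker inhibitor:
- compound 1 `CCN(C)CCCOc1ccc2cc(NC(=O)c3ccc(O)c(CC=C(C)C)c3)c(=O)oc2c1C`: 730 nM
- compound 2 `CC(C)=CCc1cc(C(=O)Nc2cc3ccc(OCCCNC(C)(C)C)c(C)c3oc2=O)ccc1O`: 660 nM

Not yet measured: compound 3 `CC(C)=CCc1cc(C(=O)Nc2cc3ccc(OCCCNCC(N)=O)c(C)c3oc2=O)ccc1O`.

Compound 2, at 660 nM, stands within the scatter of compound 1, so the two values cannot be ranked and the series has no clear leader yet. The next change is carbamoylmethyl in place of tert-butyl on an amine nitrogen.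

Among the measured compounds shown here, only one measured step bears on this change. It alters the groups on the same amine nitrogen: a 1.1-fold lower number from compound 1 to compound 2 (0.04 log units; within the scatter). That step is within the scatter, so swapping tert-butyl for ethyl and methyl left the number effectively unchanged. However, it is a single step, and neither compound 1 nor compound 2 carries carbamoylmethyl, so the data do not test this group directly. No shift clearly beyond the scatter is expected in this assay, though the uncertainty is wide and leans slightly towards a higher number. The expected change is a 1.2-fold higher number from compound 2 to compound 3 (0.08 log units; within the scatter). For compound 3 the estimated value is 800 nM, with an expected range of 300 nM to 2100 nM.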

Compound 3, half-maximal inhibitory concentration: 2290 nM
For compound 3 the middle estimate is 2.9-fold (0.46 log units) below the measured one; measured number above the stated range.
By their numbers in this assay, from the lowest: compounds 2 and 1 (each within the scatter of the next); then compound 3.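

In this assay, the group on the amine nitrogen proves able to move the number: a 3.5-fold higher number from compound 2 to compound 3 (0.54 log units; beyond the scatter), and likewise a 3.1-fold higher number from compound 1 to compound 3 (0.50 log units; beyond the scatter), whereas the earlier exchange, a 1.1-fold lower number from compound 1 to compound 2 (0.04 log units; within the scatter), showed no measurable effect. The position is therefore not indifferent to its substituent, and the difference appears with a swap that keeps the heavy-atom count of tert-butyl but replaces all-carbon groups with carbamoylmethyl, which brings in nitrogen, oxygen, a hydrogen-bond donor and a hydrogen-bond acceptor. Nothing measured here accounts for this shift.

As far as these compounds go, it remains open whether the higher number follows the terminal primary amide specifically or any group on this nitrogen that is not purely hydrocarbon, which a 2-hydroxyethyl group, a cyanomethyl group or a carboxylic acid in the same place would help to separate. Also open, from the compounds shown here alone, is whether a longer chain between the amine nitrogen and the amide, or an N-methylated amide, would keep the number of compound 3 or return it towards those of compound 1 and compound 2.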